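The compounds below may be only part of what the source reports. "The series", "measured", "known", "first", "only" and "open" are said of these compounds alone.

Measured in an ADME assay on MT4 cells (Homo sapiens) for cytotoxicity, read by MTT assay, with a stated time of 5 days; a higher number here means that more compound is tolerated, a lower number that less compound is tolerated:

- Compound 1 `Cc1cc(C)c(Oc2cc(Cl)nc(NCCn3ccc(=O)[nH]c3=O)n2)c(C)c1`: 44100 nM
- Compound 2 `Cc1cc(/C=C/C#N)cc(C)c1Oc1ccnc(NCCn2ccc(=O)[nH]c2=O)n1`: > 309000 nM (a limit of the assay, not a number)
- Compound 3 `Cc1cc(/C=C/C#N)cc(C)c1Oc1cc(N)nc(NCCn2ccc(=O)[nH]c2=O)n1`: > 298000 nM (a limit of the assay, not a number)

Going by these compounds, compound 2 gives only a limit, > 309000 nM, so its true position in this assay is unknown. Compound 3 also gives only a limit, > 298000 nM. Only compound 1 has a measured number.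

Compound 4 `Cc1cc(C)c(Oc2ccnc(NCCn3ccc(=O)[nH]c3=O)n2)c(C)c1` is reached from compound 2 by one change: methyl in place of 2-cyanoethenyl on an aromatic carbon. In short, methyl takes the place of 2-cyanoethenyl on an aromatic carbon.

Among the compounds with values here, the only measured step is a step that the two limits leave unreadable from compound 2 to compound 3. It involves a different change and gives no size to carry over. Within the data shown here, the better guide is compound 1, the only measured compound that carries the entering methyl group. Compound 1 gives 44100 nM, although it also differs from compound 4 elsewhere on the core. Compound 4 is therefore expected to lie closer to that number, with less compound tolerated than the limit of compound 2 shows. The expected step is an at least 3.8-fold lower number from compound 2 to compound 4 (0.58 log units; beyond the scatter), and its size is uncertain. For compound 4 the estimate is 80000 nM, with an expected range from 20000 nM to 340000 nM.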

Compound 4, half-maximal cytotoxic concentration: 272000 nM
Estimate against measurement, compound 4: 3.4-fold (0.53 log units) below; the measured number falls inside the stated range.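

Compound 2 stands only as a limit of the assay, not a number: the limit of > 309000 nM in this assay, at which 1 of the 4 values shown sits. Against that limit, the change from 2-cyanoethenyl to methyl at this place gives an at least 1.1-fold lower number from compound 2 to compound 4 (0.05 log units; that floor lies within the scatter), so the data do not show that this change lowers the tolerated concentration in this assay at all. With the same methyl group kept, the step is a 6.2-fold higher number from compound 1 to compound 4 (0.79 log units; beyond the scatter), for hydrogen in place of chloro on an aromatic carbon, so methyl at this place does not by itself bring the number down to the level seen with chloro on the core.

Going by these compounds, how far the true number for 2-cyanoethenyl lies from that of methyl stays unknown, and so does whether chloro on the core would also go with a lower number in a compound carrying 2-cyanoethenyl. Also open, on these data alone, is how other groups at this place, such as an amine, a carboxylic acid or a longer chain, would read in this measurement.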